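The source may hold more compounds than are shown below. What is called first, only, known or untested is meant among the compounds shown, and "the series" means these compounds.

Measured compounds:
Compound 1, `CC(C)(C)OC(=O)/C=C1/C(=O)Nc2ccccc21`: 86.1%
Compound 2, `Cc1ccc2c(c1)/C(=C\C(=O)OC(C)(C)C)C(=O)N2`: 90.3%

In a functional assay on HepG2 cells (Homo sapiens) for inhibition, read by CCK-8 assay, with a stated time of 72 h, tested at 20 uM (a lower number here means less inhibition of growth, a higher number more inhibition of growth at the concentration tested), compound 1 gives 86.1%, and compound 2 gives 90.3%. Among the compounds with values here, the only step known here, a number 4.2 percentage points higher from compound 1 to compound 2 (within the scatter), lies within the scatter, so these two numbers cannot be set apart, and compound 1 stands level with compound 2 rather than at any clear distance from it.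

Compound 3, `CC(C)(C)OC(=O)/C=C1/C(=O)Nc2c(Cl)cccc21`, differs from compound 1 by chloro in place of hydrogen on an aromatic carbon. Within the data shown here, the one measured step that bears on it, a number 4.2 percentage points higher from compound 1 to compound 2 (within the scatter), also exchanged a hydrogen on the aromatic ring of the shared core for a small group and produced no movement beyond the scatter. A single small substituent on this ring therefore gives no reason to expect a real change in this assay; a step of about a number 0.1 percentage points lower from compound 1 to compound 3 (within the scatter) is expected. For compound 3 the estimate is 86%, with a range from 74% to 95%.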

Compound 3, percent growth inhibition at one concentration: 88.1%
Estimate against measurement, compound 3: 2.1 percentage points below; the range from low to high includes it.
By their numbers in this assay, from the lowest: compounds 1, 3 and 2 (each within the scatter of the next).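

In this assay, chloro in place of hydrogen on an aromatic carbon, ortho to a fused ring and meta to a fused ring, gives a number 2 percentage points higher from compound 1 to compound 3 (within the scatter). This adds a second aromatic carbon and a second kind of small group to the methyl change seen in compound 2, and again the number does not move beyond the scatter, so neither of the two single-atom or single-carbon changes shown separates from compound 1. No measurement at hand gives a reason for this result.

On these data alone, whether a larger or very different group at this carbon, such as an amine, a carboxylic acid or a longer chain, would shift the number beyond the scatter stays open. The compounds shown also leave open how far this tolerance extends to the other aromatic carbons of the shared core.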